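The source may hold more compounds than are shown below. What is called first, only, known or untested is meant among the compounds shown, and "the series" means these compounds.

Compound 2 `CC1=CC[C@H](C(C)(C)NC(=S)N/N=C/c2ccc(O)cc2)CC1` carries a 4-hydroxyphenyl group on the carbon with a double bond to nitrogen. In a functional assay on MCF7 cells (Homo sapiens) for inhibition, read by sulforhodamine B assay, with a stated time of 48 h (on this read-out higher numbers stand for weaker inhibition of growth and lower numbers for stronger inhibition of growth), compound 2 gives only > 100000 nM, which is a limit of the assay and not a measured number. Its relatives do have numbers: compound 1 `COc1ccc(/C=N/NC(=S)NC(C)(C)[C@H]2CC=C(C)CC2)cc1` gives 31200 nM and compound 3 `CC1=CC[C@H](C(C)(C)NC(=S)N/N=C/c2ccc(N(C)C)cc2)CC1` gives 26800 nM. Replacing the hydroxy group moves the read-out downward in both comparisons, an at least 3.2-fold higher number from compound 1 to compound 2 (0.50 log units; beyond the scatter) and an at least 3.7-fold lower number from compound 2 to compound 3 (0.57 log units; beyond the scatter), with compound 2 sitting at the limit of > 100000 nM in this assay, at which 1 of the 3 values shown sits. Compound 4 `CC1=CC[C@H](C(C)(C)NC(=S)N/N=C/c2ccccc2Cl)CC1` differs by 2-chlorophenyl in place of 4-hydroxyphenyl on a carbon with a double bond to nitrogen, so the hydroxy group is again gone. A downward step is therefore expected for compound 4, estimated at 30000 nM with a range of 8000 nM to 90000 nM, meaning an at least 3.3-fold lower number from compound 2 to compound 4 (0.52 log units; beyond the scatter).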

Compound 4, concentration for 50% growth inhibition: 11000 nM
Compound 4: the middle estimate sits 2.7-fold (0.44 log units) above what was measured; measured number inside the range.
By their numbers in this assay, from the lowest: compound 4; then compounds 3 and 1 (each within the scatter of the next). At a limit, above all of these: compound 2.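

Until now, the two replacements with numbers, compound 1 and compound 3, sat within the scatter of each other. 2-Chlorophenyl on the carbon with a double bond to nitrogen goes further: against the limit of compound 2 there is an at least 9.0-fold lower number from compound 2 to compound 4 (0.95 log units; beyond the scatter), and even against a compound without the hydroxy group there is a 2.8-fold lower number from compound 1 to compound 4 (0.45 log units; beyond the scatter). So this position can still shift growth inhibition once the hydroxy group is gone.

Compound 4 differs from compound 1 in both the ring substituent and its place on the ring, so the two effects cannot be separated. From the compounds shown here alone, how a ring carrying bromine or a nitrile would read also stays open.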